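The compounds below may be only part of what the source reports. "The series", "measured", "known", "first", "only" and "open" are said of these compounds alone.

Measured in an ADME assay on HepG2 2.2.15 cells (Homo sapiens) for cytotoxicity, read by luminescence, with a stated time of 3 days; a higher number here means that more compound is tolerated, a lower number that less compound is tolerated:

- Compound 1 `O=C(Nc1ccc(F)c(Cl)c1)c1ccc(F)c(S(=O)(=O)N2CCCCC(O)CC2)c1`: 24000 nM
- Compound 2 `O=C(Nc1ccc(F)c(Cl)c1)c1ccc(F)c(S(=O)(=O)N2CCCCC(CO)C2)c1`: 3100 nM

Of these two compounds, compound 2 has the lower number, at 3100 nM. Compound 3 `CN1CCN(S(=O)(=O)c2cc(C(=O)Nc3ccc(F)c(Cl)c3)ccc2F)CC(O)C1` has not yet been measured. It carries 6-hydroxy-4-methyl-1,4-diazepan-1-yl in place of 3-(hydroxymethyl)azepan-1-yl on a sulfonyl sulfur.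

Going by the values given here, only one measured step bears on this change. It is a 7.7-fold lower number from compound 1 to compound 2 (0.89 log units; beyond the scatter), and it also replaces one ring on the sulfonyl sulfur with another. That step shows that a change at this place can move the number beyond the scatter, but it is a different exchange. Among the compounds with values here, no measured compound has a second hetero atom in the ring, so the direction rests on little. Compound 2 lies at the low end of the two values, and a move upward, of about the size of that one step or somewhat less, seems the more likely outcome. The expected change is a 4.8-fold higher number from compound 2 to compound 3 (0.68 log units; beyond the scatter). For compound 3 the estimated value is 15000 nM, with an expected range from 5000 nM to 50000 nM.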

Compound 3, half-maximal cytotoxic concentration: 31000 nM
The estimate for compound 3 lay 2.1-fold (0.32 log units) below the measured number; the measured number falls inside the stated range.
By their numbers in this assay, from the lowest: compound 2; then compounds 1 and 3 (each within the scatter of the next).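

In this assay the exchange of 3-(hydroxymethyl)azepan-1-yl for 6-hydroxy-4-methyl-1,4-diazepan-1-yl on the sulfonyl sulfur gives a 10-fold higher number from compound 2 to compound 3 (1.00 log units; beyond the scatter) and so moves the number beyond the scatter, although both groups hold a seven-membered non-aromatic ring and the same count of heavy atoms. Set against the eight-membered ring of compound 1, the same diazepane group gives a 1.3-fold higher number from compound 1 to compound 3 (0.11 log units; within the scatter), which puts compound 1 and compound 3 level and leaves compound 2 alone at the low end, so a change of ring size is not needed to separate these values. Nothing measured here accounts for the difference among these groups.

The compounds shown leave open whether the second ring nitrogen, the methyl on it or the hydroxyl in place of hydroxymethyl carries the step, for compound 3 differs from compound 2 in all of these at once. An azepan-1-yl group with a plain hydroxyl, or a 1,4-diazepan-1-yl group with no methyl, would separate these features, and how either stands in this assay is not known from these compounds.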